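Compound 3 to compound 4: chloroethyl to cyclopropyl

The compounds below may be only part of what the source reports. "The series", "measured", "known", "first", "only" and "open" are said of these compounds alone.

- compound 1 `CCCCC(=O)N(Cc1ccc(OC)c(O)c1)c1cc(OC)c(OC)c(OC)c1` gives 300 nM
- compound 2 `COc1ccc(CN(C(=O)CN=[N+]=[N-])c2cc(OC)c(OC)c(OC)c2)cc1O` gives 160 nM
- compound 3 `COc1ccc(CN(C(=O)CCCl)c2cc(OC)c(OC)c(OC)c2)cc1O` gives 110 nM

All three values come from a functional assay on KYSE-450 cells (Homo sapiens) for inhibition, read by MTT assay, with a stated time of 48 h (on this read-out higher numbers stand for weaker inhibition and lower numbers for stronger inhibition), and span a narrow range. Compound 3 sits at the low end, level with compound 2 within the scatter, as a 1.5-fold lower number from compound 2 to compound 3 (0.16 log units; within the scatter) shows. Only a 2.7-fold lower number from compound 1 to compound 3 (0.44 log units; beyond the scatter) separates it from compound 1 beyond the scatter, and that step is modest.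

Compound 4 `COc1ccc(CN(C(=O)C2CC2)c2cc(OC)c(OC)c(OC)c2)cc1O` differs from compound 3 as follows: cyclopropyl in place of 2-chloroethyl on a carbonyl carbon with cyclopropyl in place of 2-chloroethyl on a carbonyl carbon. Going by the values given here, no measured compound carries cyclopropyl, so no measured step covers this change directly. The nearest guide is a 2.7-fold lower number from compound 1 to compound 3 (0.44 log units; beyond the scatter) in which chloro enters, since compound 4 loses the chlorine and, like compound 1, has none. A small move towards a higher number in this assay is therefore expected.

The expected step is a 1.6-fold higher number from compound 3 to compound 4 (0.21 log units; within the scatter) and may well stay within the scatter. The estimated value for compound 4 is 180 nM with an expected range from 70 nM to 450 nM in this series.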

Compound 4, half-maximal inhibitory concentration: 80 nM
For compound 4 the middle estimate is 2.3-fold (0.35 log units) above the measured one, and the stated range covers the measured number.
By their numbers in this assay, from the lowest: compounds 4, 3, 2 and 1 (each within the scatter of the next, the first and the last beyond it).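

In this assay the carbonyl carbon bound to the amide-type nitrogen carries a ring as readily as an open chain: cyclopropyl stands level with 2-chloroethyl (a 1.4-fold lower number from compound 3 to compound 4 (0.14 log units; within the scatter)), so chlorine is not needed for a number at the low end of this set. Cyclopropyl also stands level with azidomethyl (a 2.0-fold lower number from compound 2 to compound 4 (0.30 log units; within the scatter)), while cyclopropyl in place of butyl gives the widest step involving compound 4, a modest one (a 3.8-fold lower number from compound 1 to compound 4 (0.57 log units; beyond the scatter)). Nothing available on these compounds accounts for any of these steps.

Still open, going by these compounds, is how this position responds to larger rings such as cyclobutyl or cyclohexyl, or to an amine or a carboxylic acid on the chain. The four compounds shown also cannot separate the effect of the ring from that of chain length, which a short unbranched chain such as ethyl would help to address.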